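This account rests on a few compounds, and the source may have more. Where it says the series, first, only, none or still open, it means among the compounds named here.

Measured compounds:
Compound 1, `CC(C)C(NC(=O)NO)C(=O)NC1CCCCC1`. In a functional assay on HEp-2 cells (Homo sapiens) for inhibition (on this read-out higher numbers stand for weaker inhibition and lower numbers for stronger inhibition), compound 1 gives only a limit of the assay, > 100000 nM.
Compound 2, `CCC(C)C(NC(=O)NO)C(=O)NC1CCCCC1`. In this assay compound 2 likewise gives only a limit, > 100000 nM.
Compound 3, `CC(C)C(NC(=O)n1nnc2ccccc21)C(=O)NC1CCCCC1`. In this assay compound 3 gives 60000 nM.

Compound 2 therefore stands at the weak end of what the assay can report: its result is a limit, not a number, and (the limit of > 100000 nM in this assay, at which 2 of the 3 values shown sit). Among the compounds with values here, the one step between measured compounds that differ in a single place, a step that the two limits leave unreadable from compound 1 to compound 2, cannot be read in size, since both ends are limits. Compound 3 differs from compound 1 in more than one respect and is not compared here as a step; its value is a number where compound 1 shows only a limit.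

Compound 4, `CCC(C)C(NC(=O)NO)C(=O)NC1CCCC1`, differs from compound 2 by cyclopentyl in place of cyclohexyl on an amide-type nitrogen. Within the data shown here, no measured step touches a change of this kind, so nothing in the numbers speaks for a shift in either direction. The expectation is that compound 4 remains close to where compound 2 sits, most likely again at a limit: in this assay compound 4 is estimated at 100000 nM, within a range of 30000 nM to 300000 nM. The step of a number no higher from compound 2 to compound 4 (the limit leaves the size open) is thus expected to be none beyond the usual scatter.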

Compound 4, half-maximal inhibitory concentration: > 100000 nM
Compound 4: a limit, no number; the forecaster's own chance of this, stated with the estimate: 80%; the middle value sits exactly at the limit.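

Compound 2 and compound 4 each give only a limit in this assay, not a number, and the step between them cannot be read in size. The compounds shown leave open how strongly compound 2 or compound 4 inhibits, and whether cyclopentyl in place of cyclohexyl on an amide-type nitrogen shifts inhibition at all.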